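A few compounds are considered here, and "the series" means these few. Any claim that something is new, unique, unknown or untested is made for them only; others in the source may bear on it.

Measured compounds in a functional assay on A-375 cells (Homo sapiens) for antiproliferative activity, read by MTT assay, with a stated time of 72 h; on this read-out higher numbers stand for weaker inhibition and lower numbers for stronger inhibition:
- compound 1 `O=C1COc2ccc(-c3cccc(NS(=O)(=O)c4ccc(F)cc4)c3)cc2N1` gives 20100 nM
- compound 2 `COc1ncc(-c2ccc3c(c2)NC(=O)CO3)cc1NS(=O)(=O)c1ccc(F)cc1` gives 26300 nM
- compound 3 `COc1cccc(N2C(=O)COc3ccc(-c4cnc(OC)c(NS(=O)(=O)c5ccc(F)cc5)c4)cc32)c1` gives only a limit, > 40000 nM

Three compounds share a bicyclic core bearing a sulfonamide-substituted aryl group. Compound 1 and compound 2 differ in their cores, and the difference between the two cores is not broken down here. Their two values in this assay lie within the scatter of each other, so no order between them can be read.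

Compound 3 carries the same change that compound 4 is about to receive: 3-methoxyphenyl in place of hydrogen on an amide-type nitrogen in a ring. Within the data shown here, the reading of compound 3 is a limit of the method, and that limit of > 40000 nM in this assay, at which 1 of the 3 values shown sits, is the only evidence on this step. Still, the step of an at least 1.5-fold higher number from compound 2 to compound 3 (0.18 log units; that floor lies within the scatter) points toward a weaker effect, at least as far as the floor of the limit allows.

Compound 4 `COc1cccc(N2C(=O)COc3ccc(-c4cccc(NS(=O)(=O)c5ccc(F)cc5)c4)cc32)c1` has not yet been measured. It arises from compound 1 through (3-methoxyphenyl in place of hydrogen on an amide-type nitrogen in a ring), and since the place of the change is described in the same words as for compound 2 and compound 3, this is the same change on a different core. Compound 4 is expected to follow the direction seen in compound 3, because the step of an at least 1.5-fold higher number from compound 2 to compound 3 (0.18 log units; that floor lies within the scatter) runs toward higher numbers. For compound 4 a step of roughly a 2.0-fold higher number from compound 1 to compound 4 (0.30 log units; within the scatter) is estimated, with a real chance that only a limit is reported. Compound 4 is therefore estimated at 40000 nM in this assay, within a range from 20000 nM to 100000 nM.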

Compound 4, half-maximal inhibitory concentration: > 40000 nM
Compound 4 was reported as a limit; the forecaster's own chance of this, stated with the estimate: 55%; the middle value lies on the limit itself.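

In this assay, 3-methoxyphenyl in place of hydrogen on the amide-type nitrogen of the core of compound 1 gives an at least 1.9-fold higher number from compound 1 to compound 4 (0.29 log units; that floor lies within the scatter), and this floor is all that can be read from the step. Together with the earlier step, this shows that the change carries over to a second core in one limited sense: on both cores the compound bearing 3-methoxyphenyl gives a limit rather than a number, but the true size of the change on each core stays unknown, and so does whether the two sizes match: the same change on two cores in this assay, an at least 1.5-fold higher number (0.18 log units; that floor lies within the scatter) from compound 2 to compound 3 and an at least 1.9-fold higher number (0.29 log units; that floor lies within the scatter) from compound 1 to compound 4; the limit leaves it open whether they differ. Even the direction of the change remains tentative, since both floors lie within the scatter and the readings for compound 3 and compound 4 cannot be told apart or placed on a scale: the limit of > 40000 nM in this assay, at which 2 of the 4 values shown sit.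

The compounds shown leave open whether a smaller group on that nitrogen, such as methyl or ethyl, would give a number that can be compared with those of compound 1 and compound 2. They also leave open whether an unsubstituted phenyl, or a phenyl ring bearing an amine or a carboxylic acid, would behave differently from 3-methoxyphenyl on either core.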